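Hydroxy in place of bromo on the hydrazone aryl

The source may hold more compounds than are shown below. What is called first, only, known or untested is meant among the compounds shown, and "the series" means these compounds.

Measured so far:
compound 1 `COc1ccc(/C=N/NC(=O)Nc2ccc(Oc3ccnc(-c4nncn4CCN(C)C)c3)c(F)c2)c(OC)c1OC` gives 7650 nM in a functional assay on U-87MG ATCC cells (Homo sapiens) for cytotoxicity, read by MTT assay, with a stated time of 72 h; on this read-out higher numbers stand for weaker inhibition and lower numbers for stronger inhibition
compound 2 `COc1cc(/C=N/NC(=O)Nc2ccc(Oc3ccnc(-c4nncn4CCN(C)C)c3)c(F)c2)cc(OC)c1OC` gives 22500 nM
compound 3 `CN(C)CCn1cnnc1-c1cc(Oc2ccc(NC(=O)N/N=C/c3cccc(Br)c3)cc2F)ccn1` gives 830 nM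

Compound 3 stands lowest of the three, with the nearest value being a 9.2-fold lower number from compound 1 to compound 3 (0.96 log units; beyond the scatter) and the furthest a 27-fold lower number from compound 2 to compound 3 (1.43 log units; beyond the scatter). The step of a 2.9-fold higher number from compound 1 to compound 2 (0.47 log units; beyond the scatter) likewise changes only the aryl on the carbon with a double bond to nitrogen. Compound 4 `CN(C)CCn1cnnc1-c1cc(Oc2ccc(NC(=O)N/N=C/c3cccc(O)c3)cc2F)ccn1` differs from compound 3 by hydroxy in place of bromo on an aromatic carbon. Among the compounds with values here, no measured step exchanges bromo for hydroxy, so the measured steps show only that this aryl group moves the number well beyond the scatter. Compound 4 is therefore expected to give a modest rise, a 3.0-fold higher number from compound 3 to compound 4 (0.48 log units; beyond the scatter), with an estimated 2500 nM in this assay, ranging from 700 nM to 9000 nM.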

Compound 4, half-maximal inhibitory concentration: > 100000 nM
Compound 4 gave a limit, no number (the forecaster's own chance of this, stated with the estimate: 5%); middle value at least 40-fold (1.60 log units) from the limit.
By their numbers in this assay, from the lowest: compound 3; then compound 1; then compound 2. At a limit, above all of these: compound 4.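

In this assay compound 4 gives a limit and not a number: the limit of > 100000 nM in this assay, at which 1 of the 4 values shown sits.
Hydroxy in place of bromo gives an at least 120-fold higher number from compound 3 to compound 4 (2.08 log units; beyond the scatter), so the single atom on this aromatic carbon can move the read-out further than either trimethoxyphenyl exchange did. The 3-hydroxyphenyl group also ranks behind both trimethoxyphenyl groups, with an at least 4.4-fold higher number from compound 2 to compound 4 (0.64 log units; beyond the scatter) and an at least 13-fold higher number from compound 1 to compound 4 (1.11 log units; beyond the scatter).

As far as these compounds go, whether the bromo itself is needed stays open, since chloro, methyl or an amine on this carbon could follow either compound 3 or compound 4. From the compounds shown here alone, the effect of hydroxy on any other carbon of this ring also remains unknown.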